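This account rests on a few compounds, and the source may have more. Where it says the series, first, only, none or still open, it means among the compounds named here.

Compound 1 `COc1ccccc1Oc1ccc2c(NCCCNCc3ccco3)ccnc2c1`: 317 10^-6 cm/s
Compound 2 `COc1ccc(Oc2ccc3c(NCCCNCc4cc(F)ccc4OC)ccnc3c2)cc1`: 317 10^-6 cm/s
Compound 3 `CC(C)CCc1ccc2c(NCCCNCc3ccco3)ccnc2c1`: 23 10^-6 cm/s

In an ADME assay for permeability, using PAMPA, with a stated time of 30 min, at pH 7.4 (a lower number here means that the compound crosses the layer more slowly, a higher number that the compound crosses the layer faster), compound 2 gives 317 10^-6 cm/s, and compound 1 gives 317 10^-6 cm/s, no change at the digits printed between the two, a gap within the scatter. Both stand well above compound 3, which gives 23 10^-6 cm/s. Among the compounds with values here, the one measured step, a 14-fold lower number from compound 1 to compound 3 (1.14 log units; beyond the scatter), is large, but it exchanges the whole aryloxy group for a chain and so does not touch the change now considered.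

Compound 4 `COc1cccc(Oc2ccc3c(NCCCNCc4cc(F)ccc4OC)ccnc3c2)c1` differs from compound 2 by 3-methoxyphenyl in place of 4-methoxyphenyl on an oxygen on an aromatic ring. Within the data shown here, no measured step covers a shift of the methoxy group around that ring. Among the measured compounds shown here, the only guide is the pair of compound 1 and compound 2, whose values show no change at the digits printed when 2-methoxyphenoxy is exchanged for 4-methoxyphenoxy. On that basis no step beyond the scatter is expected; the estimated step is a 1.1-fold lower number from compound 2 to compound 4 (0.02 log units; within the scatter). Compound 4 is therefore expected to give about 300 10^-6 cm/s, with a range from 150 10^-6 cm/s to 550 10^-6 cm/s.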

Compound 4, apparent permeability: 317 10^-6 cm/s
Compound 4: middle estimate off by 1.1-fold (0.02 log units), on the low side; low and high end bracket the measured number.
By their numbers in this assay, from the lowest: compound 3; then compounds 1, 2 and 4 (each within the scatter of the next).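

In this assay, within the data shown here, 3-methoxyphenyl in place of 4-methoxyphenyl on an oxygen on an aromatic ring gives no change at the digits printed from compound 2 to compound 4 (within the scatter) and is the first measured step that isolates this change. With the rest of compound 2 held constant, the read-out does not separate the 4-methoxyphenoxy and 3-methoxyphenoxy groups, so this shift of the methoxy group leaves the number level in this one pair. Nothing available here bears on why the two compounds match.

From the compounds shown here alone, it remains open whether 2-methoxyphenoxy would also stay level when the rest of compound 2 is held constant, and whether the same shift would do so on the side chain of compound 1. Going by these compounds, it is equally open whether a carboxylic acid or an amine in place of the methoxy group would leave the number unchanged.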